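From 3-bromophenyl to 4-fluorophenyl: a step without a guide

The source may report more compounds than this note shows. Statements on the series, on what has been measured and on what is new or still open speak of the compounds shown alone.

- compound 1 `COc1cc(OC)c(OC)cc1/C=C/COC(=O)/C=C/c1ccccc1C(F)(F)F`: > 473 umol/kg (a limit)
- compound 2 `COc1cc(OC)c(OC)cc1/C=C/COC(=O)/C=C/c1cccc(Br)c1`: > 461 umol/kg (a limit)

Both entries come from a functional assay on the whole organism (strain Kunming) with Mus musculus as the target, with a stated time of 0.5 h (a lower number here means that less compound is needed, a higher number that more compound is needed for the effect), and neither is an exact number. In this test compound 2 gives > 461 umol/kg (a limit), so its place on the scale is not fixed. Compound 1 gives > 473 umol/kg (also a limit).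

Compound 3 `COc1cc(OC)c(OC)cc1/C=C/COC(=O)/C=C/c1ccc(F)cc1` keeps the shared core of compound 2 and changes one group: 4-fluorophenyl in place of 3-bromophenyl on a double-bonded chain carbon bound to a double-bonded chain carbon.

Within the data shown here, the only measured step that bears on this exchange is a step that the two limits leave unreadable from compound 1 to compound 2 (another exchange at this place), so it offers no size or direction to carry over. No clear shift is therefore expected in this assay, and another limit is quite possible. This expectation leans on compound 2, whose > 461 umol/kg is a limit.

For compound 3 the estimated value is 480 umol/kg, with an expected range from 200 umol/kg to 800 umol/kg. The estimated step is a step that the limit leaves unreadable from compound 2 to compound 3.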

Compound 3, dose for half-maximal effect: 449 umol/kg
Beside the measured number, compound 3's estimate is 1.1-fold (0.03 log units) above it; measured number inside the range.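

In this assay, among these compounds, compound 3 gives 449 umol/kg, the only exact number among the three compounds, and the exchanges at this place read as an at least 1.0-fold lower number from compound 2 to compound 3 (0.01 log units; that floor lies within the scatter) and as an at least 1.0-fold lower number from compound 1 to compound 3 (0.02 log units; that floor lies within the scatter), so 4-fluorophenyl on a double-bonded chain carbon bound to a double-bonded chain carbon yields a readable value, but no real gain in potency can be claimed from these floors. The first step gives only a floor, not a size, because its starting value for compound 2 is a limit: the limit of > 461 umol/kg in this assay, at which 1 of the 3 values shown sits. The second step likewise gives only a floor because its starting value for compound 1 is a limit: the limit of > 473 umol/kg in this assay, at which 1 of the 3 values shown sits.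

On these data alone, how far the true values of compound 1 and compound 2 lie from that of compound 3 stays open, and the change from compound 2 to compound 3 alters both the halogen and the number in the group's name, so the two effects cannot be separated. Also open, as far as these compounds go, is what 4-bromophenyl or 3-fluorophenyl would give at this place, and what a ring carrying an amine or a carboxylic acid would give.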